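Fluoro to methoxy swap and Vero cell cytotoxicity

This account rests on a few compounds, and the source may have more. Where it says the series, first, only, none or still open, it means among the compounds named here.

Measured compounds:
Compound 1 `COc1ccc(C2SCC(=O)N2CCN2CCCCC2)cc1`; in an ADME assay on Vero cells (Chlorocebus sabaeus) for cytotoxicity, read by neutral red uptake, tested at 197 ug/mL (on this read-out lower numbers stand for a stronger effect and higher numbers for a weaker effect at the one concentration tested), compound 1 gives 87%.
Compound 2 `O=C1CSC(c2ccc(F)cc2)N1CCN1CCCCC1`; in this assay compound 2 gives 73%.
Compound 3 `O=C1CSC(c2cccc(F)c2)N1CCN1CCCCC1`; in this assay compound 3 gives 84%.

Compound 2 and compound 3 have the same atoms joined differently; the difference is 3-fluorophenyl in place of 4-fluorophenyl on a saturated ring carbon, and the step is a number 11 percentage points higher from compound 2 to compound 3 (beyond the scatter). Compound 1 and compound 3 lie within the usual scatter of each other, so nothing is said of their order.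

One swap is seen twice. From compound 2 to compound 1 it is methoxy in place of fluoro on an aromatic carbon, and the step is a number 14 percentage points higher from compound 2 to compound 1 (beyond the scatter). Compound 4 `COc1cccc(C2SCC(=O)N2CCN2CCCCC2)c1`, not yet measured, carries the same kind of change relative to compound 3: methoxy in place of fluoro on an aromatic carbon. It is not the same change, since the place differs: para to a large group in the first pair, meta to a large group here.

Within the data shown here, for compound 4 the expected step is a number 9 percentage points higher from compound 3 to compound 4 (within the scatter), taken to be of similar size to the earlier one because a number 14 percentage points higher from compound 2 to compound 1 (beyond the scatter) is the only precedent, with added uncertainty from the changed place. Compound 4 is therefore estimated at 93%, with a range from 80% to 104%.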

Compound 4, a percentage reported as activity, at one concentration (the size of the read-out at that concentration, not a potency): 66%
Beside the measured number, compound 4's estimate is 27 percentage points above it; the whole stated range lies above it.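

In this assay, methoxy in place of fluoro, meta to a large group, gives a number 18 percentage points lower from compound 3 to compound 4 (beyond the scatter). The change therefore does not carry over from one core to the other in this series, and the earlier step offers no safe guide to its direction here: the same change on two cores in this assay, a number 14 percentage points higher (beyond the scatter) from compound 2 to compound 1 and a number 18 percentage points lower (beyond the scatter) from compound 3 to compound 4, 32 percentage points apart, beyond the scatter of two such steps. This shows that the outcome of the swap depends on the fluoro compound that receives it, but it does not show what causes the reversal, and two pairs at a single concentration give no rule for any other core or any other place on the aromatic ring.

The compounds shown leave open how a group other than fluoro or methoxy would behave in the same place, for instance chloro, a hydroxyl or a nitrile, and whether any of these would follow the step seen in one pair or the other. An unsubstituted phenyl on the shared core would also give a common reference for both pairs, which the present set lacks.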